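The source may report more compounds than this note shows. Statements on the series, on what has been measured and on what is new or still open speak of the compounds shown alone.

Measured compounds in a functional assay on KYSE-70 cells for antiproliferative activity against KYSE-70 cell line (Homo sapiens), read by MTT assay, with a stated time of 72 h; on this read-out higher numbers stand for weaker inhibition and lower numbers for stronger inhibition:
compound 1, `O=C(Nc1ccc(F)cc1F)c1cc(=O)[nH]c2cc(Br)ccc12`, reads > 20000 nM, a limit of the assay
compound 2, `O=C(Nc1cc(F)cc(F)c1)c1cc(=O)[nH]c2cc(F)ccc12`, reads > 20000 nM, a limit of the assay
compound 3, `CC(C)(C)c1ccc(-c2ccc3c(C(=O)Nc4cccc(F)c4)cc(=O)[nH]c3c2)cc1`, reads > 20000 nM, a limit of the assay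

None of the three readings is a number; each is a limit. Among the measured compounds shown here, compound 3 therefore has no measured position other than the limit of > 20000 nM in this assay, at which 3 of the 3 values shown sit, and no step between measured compounds can be drawn from this set, since every value is a limit and no difference is measurable.

The unmeasured compound 4, `Cc1cc(-c2ccc3c(C(=O)Nc4cccc(F)c4)cc(=O)[nH]c3c2)c(C)cc1F`, differs from compound 3 in one place: 4-fluoro-2,5-dimethylphenyl in place of 4-(tert-butyl)phenyl on an aromatic carbon. In this assay the expected step is a number no higher from compound 3 to compound 4 (the limit leaves the size open), none beyond the scatter, and the reading for compound 4 is expected to be a limit again rather than a number. Compound 4 is expected at 20000 nM, with a range from 8000 nM to 40000 nM.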

Compound 4, half-maximal inhibitory concentration: > 20000 nM
Compound 4: a limit, no number; the forecaster's own chance of this, stated with the estimate: 75%; the middle value sits exactly at the limit.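

In this assay, compound 3 and compound 4 both read as limits, not numbers, so no step can be read between them: the limit of > 20000 nM in this assay, at which 4 of the 4 values shown sit.

The compounds shown leave open how far apart they lie in this assay, and which change to the shared core, if any, would give a numerical reading.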